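This account rests on a few compounds, and the source may have more. Where it says the series, first, only, none or still open, it means among the compounds named here.

Compound 1 `O=C(NCc1cc(Cl)ccc1-n1cnnn1)[C@@H]1C[C@@H]2C[C@@H]2N1C(=O)[C@H](O)C1CCCCC1`: 600 nM
Compound 2 `O=C(NCc1cc(Cl)ccc1-n1cnnn1)[C@@H]1C[C@H]2C[C@H]2N1C(=O)[C@H](O)c1cccc(F)c1`: 1100 nM

Both numbers come from a functional assay on a cell-free system (plasma, Homo sapiens), with a stated time of 3 min; a higher number here means a weaker inhibitor, a lower number a stronger inhibitor. Compound 1 stands level with compound 2, since their two values lie within the usual scatter of each other and cannot be ranked.

Compound 3 `O=C(NCc1cc(Cl)ccc1-n1cnnn1)[C@@H]1C[C@@H]2C[C@@H]2N1C(=O)[C@H](O)c1ccccc1F` has not yet been measured. It keeps the core of compound 1 and changes one group: 2-fluorophenyl in place of cyclohexyl on a saturated chain carbon bound to a carbonyl carbon and an oxygen on a saturated carbon. A non-aromatic ring thus gives way to an aromatic ring of the same size.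

Among the compounds with values here, no measured pair isolates this change, so the data give no direct size for the step. The nearest guide is compound 2, which also carries a fluorinated aromatic ring on that carbon and gives 1100 nM. On that basis, a small shift towards a weaker inhibitor is expected, with no step beyond the scatter. The estimated step is a 1.7-fold higher number from compound 1 to compound 3 (0.22 log units; within the scatter). For compound 3 the expected value is 1000 nM, with an estimated range of 300 nM to 3000 nM.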

Compound 3, half-maximal inhibitory concentration: 770 nM
Compound 3: middle estimate off by 1.3-fold (0.11 log units), on the high side; the range from low to high includes it.
By their numbers in this assay, from the lowest: compounds 1, 3 and 2 (each within the scatter of the next).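

In this assay, placing 2-fluorophenyl in place of cyclohexyl on the saturated chain carbon bound to a carbonyl carbon and an oxygen on a saturated carbon gives a 1.3-fold higher number from compound 1 to compound 3 (0.11 log units; within the scatter). Within the data shown here, compound 1 and compound 3 are the first pair here that differ only at this place, and they show that a non-aromatic ring of carbon only and a fluorinated aromatic ring of the same size cannot be told apart at this position in this measurement, so the position accepts both kinds of six-membered ring. No measurement available here bears on what lies behind this result.

The compounds shown leave open how much of this reading belongs to the aromatic ring and how much to the fluorine, a question that a plain phenyl group at this place would address. They also leave open what happens on this carbon without a six-membered ring at all: a methyl group, a longer chain, an amine or a carboxylic acid might give quite a different number from these two rings.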